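The source may report more compounds than this note shows. Statements on the series, on what has been measured and on what is new or still open speak of the compounds shown alone.

The series shares the core of compound 2, `O=C(COc1cccc2ccccc12)N/N=C/c1ccc(Cl)cc1`. In an ADME assay on HEL cells (Homo sapiens) for cytotoxicity (a higher number here means that more compound is tolerated, a lower number that less compound is tolerated), compound 2 gives 100 ug/mL. Compound 3, `O=C(COc1cccc2ccccc12)N/N=C/c1cccc(O)c1`, carries a 3-hydroxyphenyl in place of the 4-chlorophenyl on the carbon with a double bond to nitrogen, and in this assay compound 3 gives 100 ug/mL. The step of no change at the digits printed from compound 2 to compound 3 (within the scatter) therefore lies within the scatter. Compound 1, `COc1ccc(/C=N/NC(=O)COc2cccc3ccccc23)cc1OC`, is reported in this assay only as a limit, >= 20 ug/mL. Compound 3 thus stands level with compound 2 at the digits shown; its nearest neighbour is compound 2, and one further value in the set is a limit rather than a number. the limit of >= 20 ug/mL in this assay, at which 1 of the 3 values shown sits, offers no number to compare against.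

Compound 4, `COc1ccc(/C=N/NC(=O)COc2cccc3ccccc23)cc1O`, differs from compound 3 in one place: methoxy in place of hydrogen on an aromatic carbon. Going by the values given here, no measured step adds a methoxy group, so the only step that bears on it is no change at the digits printed from compound 2 to compound 3 (within the scatter), which exchanged the whole aryl group without moving the read-out beyond the scatter. A methoxy entering on the same aromatic ring is expected to leave this assay unchanged beyond the scatter. The step of no change at the digits printed from compound 3 to compound 4 (within the scatter) is therefore expected to stay within it. For compound 4 the estimate in this assay is 100 ug/mL, in the range 40 ug/mL to 200 ug/mL.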

Compound 4, minimum cytotoxic concentration: 100 ug/mL
For compound 4 middle estimate and measured number coincide at the digits printed, and the stated range covers the measured number.
By their numbers in this assay, from the lowest: compounds 2, 3 and 4 (each within the scatter of the next).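

In this assay, methoxy in place of hydrogen on an aromatic carbon, ortho to a hydroxy group and para to a large group, gives no change at the digits printed from compound 3 to compound 4 (within the scatter). The earlier step exchanged the whole aryl group, whereas this one adds a single group of 2 heavy atoms to a ring that keeps its hydroxy group, and the read-out stays within the scatter at this position. Compound 1 is reported only as a limit, >= 20 ug/mL, and the step that replaces its methyl on an oxygen on an aromatic ring with hydrogen cannot be read: the limit of >= 20 ug/mL in this assay, at which 1 of the 4 values shown sits.

On these data alone, whether this carbon accepts an amine, a carboxylic acid or a longer chain such as butoxy with the same lack of movement in the read-out remains open. All compounds with a numeric value sit level with one another, so the series shown contains no change that moves the read-out beyond the scatter, and which part of the shared core, if any, would produce such a change also remains open.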